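Compound 4: naphthalen-2-yl in place of 4-fluorophenyl

This account rests on a few compounds, and the source may have more. Where it says the series, first, only, none or still open, it means among the compounds named here.

Of the compounds shown here, three on a shared core have been tested in a functional assay on A549 cells (Homo sapiens) for inhibition, read by MTT assay, with a stated time of 24 h; a higher number here means a weaker inhibitor, a lower number a stronger inhibitor. Compound 1 `CCOC(=O)C1=Cc2ccccc2OC1(OCc1cn(-c2ccc(F)cc2)nn1)C(F)(F)F` gives 7300 nM. Among the compounds with values here, compound 3 `CCOC(=O)C1=Cc2ccccc2OC1(OCc1cn(CC(=O)Nc2ccc(C)cc2)nn1)C(F)(F)F` gives 54300 nM, and the single measured step between neighbours is a 7.4-fold higher number from compound 1 to compound 3 (0.87 log units; beyond the scatter), a change on the aromatic nitrogen. Compound 2 `O=C(O)C1=Cc2ccccc2OC1(OCc1cc(-c2ccc(F)cc2)no1)C(F)(F)F` carries a free carboxylic acid and a different five-membered ring. For compound 2 this assay reports only a limit, > 150000 nM, so it has no exact number. That places compound 2 at the limit of > 150000 nM in this assay, at which 1 of the 3 values shown sits, the weak end of what the measurement can record.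

Compound 4 `O=C(O)C1=Cc2ccccc2OC1(OCc1cc(-c2ccc3ccccc3c2)no1)C(F)(F)F` differs from compound 2 in one place: naphthalen-2-yl in place of 4-fluorophenyl on an aromatic carbon. Within the data shown here, no measured step touches this exchange, since the only step recorded concerns compound 1 and compound 3 and a different position and group. The size and direction of the change in this assay therefore cannot be read from the data, and compound 2 itself offers only a floor, not a number to move from.

Compound 4 is expected to give roughly 100000 nM, in a wide band from 20000 nM to 300000 nM. The expected step from compound 2 is an at least 1.5-fold lower number from compound 2 to compound 4 (0.17 log units; that floor lies within the scatter), with a real chance that the assay again reports only a limit.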

Compound 4, half-maximal inhibitory concentration: > 150000 nM
Compound 4 ended at the assay's limit; the forecaster's own chance of this, stated with the estimate: 50%; middle value at least 1.5-fold (0.17 log units) from the limit.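

In this assay, within the data shown here, compound 2 and compound 4 both stop at the assay's limit rather than giving exact numbers, so no step between them can be read: the limit of > 150000 nM in this assay, at which 2 of the 4 values shown sit. From the compounds shown here alone, what remains open is whether naphthalen-2-yl in place of 4-fluorophenyl changes the result at all, and in which direction.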